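This account rests on a few compounds, and the source may have more. Where it says the series, first, only, none or still open, it means among the compounds named here.

Compound 1 `CN(CCC(Oc1cccc(C(F)(F)F)c1)c1ccccc1)CC(=O)O` gives 2510 nM in an assay on CHO cells for inhibition of sodium- and chloride-dependent glycine transporter 1 (Homo sapiens) (a higher number here means a weaker inhibitor, a lower number a stronger inhibitor), the highest number of the three measured. Compound 2 `CN(CC[C@@H](Oc1ccc(-c2ccccc2)cc1)c1ccccc1)CC(=O)O` gives 151 nM in this assay, and compound 3 `CN(CC[C@H](Oc1ccc(-c2ccccc2)cc1)c1ccccc1)CC(=O)O` gives 977 nM in this assay; the step of a 6.5-fold higher number from compound 2 to compound 3 (0.81 log units; beyond the scatter) rests only on (the fact that compounds 2 and 3 differ only in the configuration as drawn). Compound 4 `CN(CCC(Oc1ccc(Cl)c(C(F)(F)F)c1)c1ccccc1)CC(=O)O` carries chloro in place of hydrogen on an aromatic carbon, ortho to the trifluoromethyl group and para to a large group. Among the compounds with values here, no measured step changes a substituent on this ring; the one known step concerns configuration alone and does not bear on an added chloro. An estimated step of a 1.6-fold lower number from compound 1 to compound 4 (0.20 log units; within the scatter) is therefore expected, within the scatter or slightly lower. Compound 4 is expected to give 1600 nM in this assay, with a range from 500 nM to 5000 nM.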

Compound 4, half-maximal inhibitory concentration: 398 nM
Estimate against measurement, compound 4: 4.0-fold (0.60 log units) above; the measured number lies below the stated range.
By their numbers in this assay, from the lowest: compound 2; then compound 4; then compound 3; then compound 1.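

In this assay, within the data shown here, chloro in place of hydrogen on this aromatic carbon, ortho to a trifluoromethyl group and para to a large group, gives a 6.3-fold lower number from compound 1 to compound 4 (0.80 log units; beyond the scatter) and is the first measured substituent step. This position therefore accepts a chlorine atom, and the number falls beyond the scatter. Nothing at hand bears on why this change lowers the number.

Still open, going by these compounds, is whether a fluoro, methyl or methoxy group at this position would act in the same way. Also open, on these data alone, is whether chloro gives a similar step on a ring without the trifluoromethyl group.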